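Cinnamamide series: expectation for compound 3

The source may report more compounds than this note shows. Statements on the series, on what has been measured and on what is new or still open speak of the compounds shown alone.

Compound 1 `COc1ccc(/C=C/C(=O)Nc2cc(C(=O)c3cc(OC)c(OC)c(OC)c3)ccc2OC)cc1` in a functional assay on B16 cells (Mus musculus) for cytotoxicity, read by MTT assay, with a stated time of 72 h (on this read-out lower numbers stand for stronger inhibition and higher numbers for weaker inhibition), gives 8700 nM.
Compound 2 `C#CCOc1cccc(/C=C/C(=O)Nc2cc(C(=O)c3cc(OC)c(OC)c(OC)c3)ccc2OC)c1` in this assay gives 12200 nM.

Compound 2 holds the higher of the two numbers; its nearest neighbour is compound 1, and the step of a 1.4-fold higher number from compound 1 to compound 2 (0.15 log units; within the scatter) stays within the scatter. Compound 3 `COc1ccc(C(=O)c2cc(OC)c(OC)c(OC)c2)cc1NC(=O)/C=C/c1ccc(C(F)(F)F)cc1` differs from compound 2 by 4-(trifluoromethyl)phenyl in place of 3-(propargyloxy)phenyl on a double-bonded chain carbon bound to a double-bonded chain carbon. Among the measured compounds shown here, no measured step covers this exchange; the one step available swaps groups at the same place and did not move the number beyond the scatter. On that basis no step beyond the scatter is expected from compound 2 to compound 3, i.e. a 1.2-fold lower number from compound 2 to compound 3 (0.09 log units; within the scatter). Compound 3 is therefore estimated at 10000 nM, within 3000 nM to 40000 nM.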

Compound 3, half-maximal inhibitory concentration: 100 nM
Compound 3: middle estimate off by 100-fold (2.00 log units), on the high side, and the stated range ends above it.
By their numbers in this assay, from the lowest: compound 3; then compounds 1 and 2 (each within the scatter of the next).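

In this assay this place proves far from indifferent to the group it carries: 4-(trifluoromethyl)phenyl stands well apart from both 3-(propargyloxy)phenyl (a 120-fold lower number from compound 2 to compound 3 (2.09 log units; beyond the scatter)) and 4-methoxyphenyl (an 87-fold lower number from compound 1 to compound 3 (1.94 log units; beyond the scatter)). The earlier exchange at the same place, by contrast, stayed within the scatter. No measurement here bears on what lies behind the large steps.

As far as these compounds go, it remains open whether the step belongs to trifluoromethyl itself or to where it sits on the ring. Both a 3-(trifluoromethyl)phenyl and a 4-chlorophenyl at this place would help separate the two.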